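A few compounds are considered here, and "the series" means these few. Any claim that something is new, unique, unknown or untested is made for them only; others in the source may bear on it.

The series shares one core, seen in compound 1 `CC(=O)c1ccc(N2CCN(C(=O)c3nc4cc(Cl)ccc4s3)CC2)cc1` and compound 2 `O=C(c1nc2cc(Cl)ccc2s1)N1CCN(c2cnccn2)CC1`. In an ADME assay on RAW264.7 cells (Mus musculus) for cytotoxicity, read by MTT assay, with a stated time of 72 h, tested at 50 ug/mL (on this read-out lower numbers stand for less inhibition and higher numbers for more inhibition at the one concentration tested (going by the name of the read-out)), compound 1 gives 30.8%, and in this assay compound 2 gives 54.9%. Going by the values given here, the only measured step runs a number 24.1 percentage points higher from compound 1 to compound 2 (beyond the scatter), and compound 2 therefore stands highest of the two numbers so far, with compound 1 as its nearest neighbour beyond the scatter.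

Compound 3 `COc1ccccc1N1CCN(C(=O)c2nc3cc(Cl)ccc3s2)CC1` is not yet measured. It differs from compound 2 by 2-methoxyphenyl in place of pyrazin-2-yl on an amine nitrogen in a ring. The step from compound 1 to compound 2 is the only one that bears on this change, as it also exchanges the group on the same ring nitrogen, and it was modest in size, though it compares two groups that are neither of them the one that enters here. Since that step moved the read-out upward when 4-acetylphenyl was replaced by pyrazin-2-yl, and compound 3 again carries an aromatic ring of carbon only, the step of a number 16.9 percentage points lower from compound 2 to compound 3 (beyond the scatter) is expected to run downward, toward the level of compound 1. Compound 3 is estimated at 38% in this assay, with a range from 20% to 58%.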

Compound 3, a percentage reported as inhibition, at one concentration (the size of the read-out at that concentration, not a potency): 63.4%
For compound 3 the middle estimate is 25.4 percentage points below the measured one; the whole stated range lies below it.
By their numbers in this assay, from the lowest: compound 1; then compounds 2 and 3 (each within the scatter of the next).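

In this assay the exchange of pyrazin-2-yl for 2-methoxyphenyl on the amine nitrogen in the ring gives a number 8.5 percentage points higher from compound 2 to compound 3 (within the scatter) and so does not separate the two groups, although one ring carries 2 hetero atoms and the other is of carbon only. The other new comparison, a number 32.6 percentage points higher from compound 1 to compound 3 (beyond the scatter), joins two groups that both have a six-membered aromatic ring of carbon only, which shows that such a ring at this nitrogen does not in itself keep the number at the level of compound 1; of the three compounds, only compound 1, with its 4-acetylphenyl, stands apart from the others beyond the scatter. Nothing available gives a measured reason for this pattern.

The 4-acetylphenyl of compound 1 and the 2-methoxyphenyl of compound 3 differ both in the attached group and in its place on the ring, so these compounds cannot show which of the two matters. Also open, as far as these compounds go, is how this read-out responds when the same nitrogen carries a non-aromatic group such as a methyl or a benzyl, or when the aromatic ring there bears a carboxylic acid.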